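A few compounds are considered here, and "the series" means these few. Any claim that something is new, unique, unknown or untested is made for them only; others in the source may bear on it.

Compounds measured in a functional assay on HT-29 cells (Homo sapiens) for inhibition, read by sulforhodamine B assay, with a stated time of 48 h; a lower number here means a stronger inhibitor of growth, a higher number a weaker inhibitor of growth:
Compound 1, `COc1cc2cc(Oc3ccc(NC(=O)Nc4cccc(C(F)(F)F)c4)cc3)c(C)nc2cc1OC`, gives 6260 nM.
Compound 2, `COc1cc2cc(Oc3ccc(NC(=O)Nc4ccc(Cl)c(C(F)(F)F)c4)cc3)c(C)nc2cc1OC`, gives 3980 nM.

Compound 2 stands at the smaller of these two numbers, but compound 1 lies within the scatter of it, so the two cannot be ranked. Among the compounds with values here, the only step measured, a 1.6-fold lower number from compound 1 to compound 2 (0.20 log units; within the scatter), came from chloro in place of hydrogen on an aromatic carbon.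

Compound 3, `COc1cc2cc(Oc3ccc(NC(=O)Nc4ccc(Cl)c(Cl)c4)cc3)c(C)nc2cc1OC`, is the next compound. It differs from compound 2 by chloro in place of trifluoromethyl on an aromatic carbon. Within the data shown here, no measured step exchanges trifluoromethyl for chloro, so this change is untested here. Among the measured compounds shown here, the one step that touches the same ring, a 1.6-fold lower number from compound 1 to compound 2 (0.20 log units; within the scatter), stayed within the scatter. With no evidence for a shift in either direction, the step expected from compound 2 to compound 3, a 1.1-fold higher number from compound 2 to compound 3 (0.05 log units; within the scatter), is none beyond the scatter. Compound 3 is therefore estimated at 4500 nM in this assay, with a range from 1500 nM to 13000 nM.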

Compound 3, concentration for total growth inhibition: 4890 nM
Estimate against measurement, compound 3: 1.1-fold (0.04 log units) below; measured number inside the range.
By their numbers in this assay, from the lowest: compounds 2, 3 and 1 (each within the scatter of the next).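

In this assay, within the data shown here, chloro in place of trifluoromethyl on the aromatic carbon ortho to a chloro group gives a 1.2-fold higher number from compound 2 to compound 3 (0.09 log units; within the scatter) and so leaves the two groups indistinguishable at this position, which the earlier compounds, differing only by the added chloro, could not show. Taken together, the two changes that make up 3,4-dichlorophenyl in place of 3-(trifluoromethyl)phenyl give a 1.3-fold lower number from compound 1 to compound 3 (0.11 log units; within the scatter) and so also produce no readable difference, leaving all three compounds unranked. Nothing measured here explains why these groups are interchangeable in this assay.

On these data alone, whether a nitrile, an amine or a carboxylic acid at this position would move the number beyond the scatter remains open. So does whether a change elsewhere on this ring, such as a methoxy group in place of the chloro, would do so.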